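The source may report more compounds than this note shows. Statements on the series, on what has been measured and on what is new or still open speak of the compounds shown alone.

Among the compounds with values here, compound 1 `COc1cc(O)cc(O)c1C(=O)/C=C/c1ccc(O)cc1` gives 48100 nM in a functional assay on HeLa cells (Homo sapiens) for inhibition, read by MTT assay, with a stated time of 72 h (a higher number here means a weaker inhibitor, a lower number a stronger inhibitor), the higher of the two numbers measured so far; its nearest neighbour is compound 2 `COc1ccc(/C=C/C(=O)c2c(O)cc(O)cc2OC)cc1`, which gives 47700 nM, so that the step of a 1.0-fold lower number from compound 1 to compound 2 (0.00 log units; within the scatter) stays within the scatter. Compound 3 `COc1cc(O)cc(O)c1C(=O)/C=C/c1ccc(O)c(O)c1` differs from compound 1 by hydroxy in place of hydrogen on an aromatic carbon. Within the data shown here, no measured step involves a hydroxy entering an aromatic carbon, and the only step available, from compound 1 to compound 2, was flat. For compound 3 the expected change is therefore small, a 1.2-fold lower number from compound 1 to compound 3 (0.08 log units; within the scatter), and compound 3 is estimated at 40000 nM, within 15000 nM to 110000 nM.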

Compound 3, half-maximal inhibitory concentration: 21300 nM
For compound 3 the middle estimate is 1.9-fold (0.27 log units) above the measured one; the measured number falls inside the stated range.
By their numbers in this assay, from the lowest: compound 3; then compounds 2 and 1 (each within the scatter of the next).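

Putting a hydroxy on this aromatic carbon, ortho to a hydroxy group, gives a 2.3-fold lower number from compound 1 to compound 3 (0.35 log units; beyond the scatter) in this assay. Unlike the flat step between compound 1 and compound 2, this is a change that clears the scatter, so this position can shift the number, though only modestly. No available evidence explains why the added hydroxy has this effect.

The compounds shown leave open whether this shift is specific to hydroxy, as a methoxy, an amine or a chlorine atom on the same carbon could behave differently. From the compounds shown here alone, whether a second change elsewhere would add to it also remains unknown.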